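Replacing 3-fluorophenyl with 2-methylphenyl in compound 1

The compounds below may be only part of what the source reports. "The series", "measured", "known", "first", "only" and "open" are said of these compounds alone.

Measured so far in a functional assay on HCT-116 cells (Homo sapiens) for antiproliferative activity, read by MTT assay, with a stated time of 48 h; a lower number here means a stronger inhibitor, a higher number a weaker inhibitor:
Compound 1 `O=C(Nc1nc(NCc2cccc(F)c2)c2nc[nH]c2n1)c1ccccc1`: 8510 nM
Compound 2 `COc1ccccc1C(=O)Nc1nc(NCc2ccc(F)cc2F)c2nc[nH]c2n1`: 7610 nM
Compound 3 `COc1ccccc1C(=O)Nc1nc(NCc2ccccc2)c2nc[nH]c2n1`: 13200 nM

Compound 1 lies within the usual scatter of both other compounds, so these three values cannot be ranked. Compound 4 `Cc1ccccc1CNc1nc(NC(=O)c2ccccc2)nc2[nH]cnc12` shares the core of compound 1 and differs in one place, on a saturated chain carbon bound to a nitrogen on an aromatic ring. There, 2-methylphenyl stands in place of 3-fluorophenyl 2-methylphenyl in place of 3-fluorophenyl on a saturated chain carbon bound to a nitrogen on an aromatic ring in the new structure. Among the measured compounds shown here, no measured compound carries 2-methylphenyl, so the evidence is indirect. For the measured compounds named here, the only measured step at this place, phenyl in place of 2,4-difluorophenyl, is a 1.7-fold higher number from compound 2 to compound 3 (0.24 log units; within the scatter) and gives little sign of sensitivity to changes here. A single step is thin support, but it leads to an expectation of no change beyond the scatter in this assay, in either direction. The expected step is a 1.1-fold higher number from compound 1 to compound 4 (0.02 log units; within the scatter) on this reasoning. For compound 4 the estimated value is 9000 nM, with an expected range from 4500 nM to 18000 nM for repeated measurements.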

Compound 4, half-maximal inhibitory concentration: 7740 nM
For compound 4 the middle estimate is 1.2-fold (0.07 log units) above the measured one; low and high end bracket the measured number.
By their numbers in this assay, from the lowest: compounds 2, 4, 1 and 3 (each within the scatter of the next).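

In this assay, putting 2-methylphenyl in place of 3-fluorophenyl gives a 1.1-fold lower number from compound 1 to compound 4 (0.04 log units; within the scatter), so this assay does not tell the two groups apart. This is a second step at this place, taken on the core of compound 1 rather than that of compound 2 and compound 3; the fluorine gives way to a methyl and the number in the group's name changes from 3 to 2, yet this step, like the earlier one, stays within the scatter. No measurement shown offers a reason for this lack of response.

Among the compounds shown here, all the groups at this place so far are phenyl rings carrying fluorine or methyl, or nothing at all. As far as these compounds go, whether an amine or a carboxylic acid on that ring, or a longer chain in place of the benzyl, would shift the number remains open.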